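The source may report more compounds than this note shows. Statements on the series, on what has been measured and on what is new or still open speak of the compounds shown alone.

Of the compounds shown here, three built on one shared core have been tested in a functional assay for inhibition of sodium/hydrogen exchanger (Oryctolagus cuniculus); on this read-out lower numbers stand for stronger inhibition and higher numbers for weaker inhibition. Compound 1 `CCCc1cc(C)c(C(=O)N=C(N)N)cc1S(C)(=O)=O` gives 5.7 nM, compound 2 `Cc1cc(C2CCCCC2)c(S(C)(=O)=O)cc1C(=O)N=C(N)N` gives 22 nM, and compound 3 `Cc1cc(-c2ccc(Cl)cc2Cl)c(S(C)(=O)=O)cc1C(=O)N=C(N)N` gives 42 nM. Compound 3 sits at the high end of the numbers shown, clearly apart only from compound 1: the steps are a 7.4-fold higher number from compound 1 to compound 3 (0.87 log units; beyond the scatter) and a 1.9-fold higher number from compound 2 to compound 3 (0.28 log units; within the scatter), while a 3.9-fold higher number from compound 1 to compound 2 (0.59 log units; beyond the scatter). Compound 4 `CCCSc1cc(C)c(C(=O)N=C(N)N)cc1S(C)(=O)=O` differs from compound 3 in one place: propylsulfanyl in place of 2,4-dichlorophenyl on an aromatic carbon. The step that bears on this most is a 7.4-fold higher number from compound 1 to compound 3 (0.87 log units; beyond the scatter), and the change here largely reverses it, swapping back to a short chain of similar length. Compound 4 is therefore expected to show a clearly lower number than compound 3, about a 4.7-fold lower number from compound 3 to compound 4 (0.67 log units; beyond the scatter). The estimate for compound 4 is 9 nM, with a range from 3 nM to 30 nM.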

Compound 4, half-maximal inhibitory concentration: 6.8 nM
Beside the measured number, compound 4's estimate is 1.3-fold (0.12 log units) above it; the measured number falls inside the stated range.
By their numbers in this assay, from the lowest: compounds 1 and 4 (each within the scatter of the next); then compounds 2 and 3 (each within the scatter of the next).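

Swapping the carbon-linked propyl for propylsulfanyl at this position, ortho to a methylsulfonyl group, leaves the number within the scatter: a 1.2-fold higher number from compound 1 to compound 4 (0.08 log units; within the scatter). Compound 4 also stands clearly apart from the compounds carrying ring groups, with a 6.2-fold lower number from compound 3 to compound 4 (0.79 log units; beyond the scatter) and a 3.2-fold lower number from compound 2 to compound 4 (0.51 log units; beyond the scatter), so among these four compounds, the two open chains separate from cyclohexyl and 2,4-dichlorophenyl. No measurement here explains this split. Going by these compounds, whether a longer chain, such as hexyl, or a chain ending in an amine would stay with the open chains remains open.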